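Chloro for fluoro at the limit of stability

The source may hold more compounds than are shown below. What is called first, only, known or untested is meant among the compounds shown, and "the series" means these compounds.

In an ADME assay on microsomes from liver (Canis lupus familiaris) for metabolic stability (a lower number here means that the compound disappears faster, a higher number that the compound lasts longer), compound 3 `Nc1nc(NCCNc2ncc(-c3ncc[nH]3)c(-c3ccc(F)cc3F)n2)ccc1[N+](=O)[O-]` has no number, only a limit. Compound 3 gives the limit > 0.5 h. Compound 1 `N#Cc1ccc(NCCNc2ncc(-c3ncc[nH]3)c(-c3ccc(Cl)cc3Cl)n2)nc1` gives the limit > 0.5 h. Compound 2 `Nc1nc(NCCNc2ncc(-c3ncc[nH]3)c(-c3ccccc3Cl)n2)ccc1[N+](=O)[O-]`, with its 2-chlorophenyl, gives the limit > 0.5 h. All of these sit at one mark (the limit of > 0.5 h in this assay, at which 3 of the 3 values shown sit). Compound 4 `Nc1nc(NCCNc2ncc(-c3ncc[nH]3)c(-c3ccc(F)cc3Cl)n2)ccc1[N+](=O)[O-]` differs from compound 3 by chloro in place of fluoro on an aromatic carbon. Going by the values given here, the one measured step that bears on this, a step that the two limits leave unreadable from compound 2 to compound 3, has no readable size and gives no direction. No shift beyond the scatter is therefore expected, and the estimated step is a step that the limit leaves unreadable from compound 3 to compound 4. Compound 4 is expected at 0.7 h, with an estimated range of 0.5 h to 1.5 h, most likely reported as a limit again.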

Compound 4, half-life: > 0.5 h
Compound 4 was reported as a limit; the forecaster's own chance of this, stated with the estimate: 85%; the middle value is on the limit's open side.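

Compound 4 is reported as a limit, as are compound 2 and compound 3, so no step among these three compounds can be read: the limit of > 0.5 h in this assay, at which 4 of the 4 values shown sit.

On these data alone, how long any of the four compounds actually lasts, and whether chloro in place of fluoro changes that, stays open.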